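Compound 4: a hydroxypiperidine chain in place of the triazole arm

The source may hold more compounds than are shown below. What is called first, only, known or untested is meant among the compounds shown, and "the series" means these compounds.

Compound 1 `O=C1c2c[n+]([O-])c3ccccc3c2C(=O)c2c1c1ccccc1n2Cc1cn(CC(O)CO)nn1`: in a functional assay on MCF7 cells (Homo sapiens) for cytotoxicity, read by MTT assay, with a stated time of 72 h (a lower number here means a stronger inhibitor, a higher number a weaker inhibitor), compound 1 gives 1110 nM.
Compound 2 `CC1(C)OC[C@@H](Cn2cc(Cn3c4c(c5ccccc53)C(=O)c3c[n+]([O-])c5ccccc5c3C4=O)nn2)O1`: compound 2 gives only a limit of the assay, > 1000 nM.
Compound 3 `O=C1c2c[n+]([O-])c3ccccc3c2C(=O)c2c1c1ccccc1n2Cc1cn([C@@H]2O[C@H](CO)[C@@H](O)[C@H](O)[C@H]2O)nn1`: compound 3 gives 590 nM.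

Compound 1 carries the highest number among the two measured values; the step of a 1.9-fold lower number from compound 1 to compound 3 (0.27 log units; within the scatter) is within the scatter, and the step that the limit leaves unreadable from compound 1 to compound 2 cannot be read because of the limit of > 1000 nM in this assay, at which 1 of the 3 values shown sits. Going by the values given here, the series so far varies only the group on the triazole nitrogen, and none of these steps is resolved beyond the scatter.

Compound 4 `O=C1c2c[n+]([O-])c3ccccc3c2C(=O)c2c1c1ccccc1n2CCCN1CCC(O)CC1` removes that triazole altogether: 2-(4-hydroxypiperidin-1-yl)ethyl in place of 1-(2,3-dihydroxypropyl)-1H-1,2,3-triazol-4-yl on a saturated chain carbon bound to an aromatic nitrogen. Among the compounds with values here, no measured step touches this part of the molecule, so the shared core is the only point of reference, and the measured steps give no direction to expect. The expectation is therefore a step of no clear sign, within the scatter, and compound 4 is estimated at 900 nM, between 300 nM and 3000 nM, which means an expected step of a 1.2-fold lower number from compound 1 to compound 4 (0.09 log units; within the scatter). Given that compound 2 sits at the limit (the limit of > 1000 nM in this assay, at which 1 of the 3 values shown sits), a limit rather than a number is also a real possibility for compound 4.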

Compound 4, half-maximal inhibitory concentration: 190 nM
For compound 4 the middle estimate is 4.7-fold (0.68 log units) above the measured one; measured number outside the range, below it.
By their numbers in this assay, from the lowest: compound 4; then compounds 3 and 1 (each within the scatter of the next).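

In this assay, going by these compounds alone, the step of a 5.8-fold lower number from compound 1 to compound 4 (0.77 log units; beyond the scatter) is the only readable step that lies beyond the scatter, and it comes from a change on a saturated chain carbon bound to an aromatic nitrogen. The earlier readable steps altered only the group on the triazole nitrogen and stayed within the scatter, whereas replacing the whole 1-(2,3-dihydroxypropyl)-1H-1,2,3-triazol-4-yl group with 2-(4-hydroxypiperidin-1-yl)ethyl shows that this position can respond in the cytotoxicity read-out. No measurement shown accounts for this step.

The triazole, the chain and the hydroxypiperidine ring change together in this single step, so the compounds shown do not assign the difference to any one of them. Still open, on these data alone, is whether the step survives with a plain piperidine lacking the hydroxyl, a morpholine or a dimethylamino group at the chain end, or with a shorter or longer chain leading to the 4-hydroxypiperidin-1-yl group.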